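The compounds below may be only part of what the source reports. "The series", "measured", "known", "first", "only" and "open" are said of these compounds alone.

Measured so far:

- Compound 1, `COC1=C(C)C(=O)/C(=C(O)/C=C/c2ccc(Br)cc2)C(=O)C1(C)C`, gives 1.4 ug/mL in a functional assay on A549 cells (Homo sapiens) for cytotoxicity; on this read-out higher numbers stand for an effect only at larger amounts of compound and lower numbers for an effect already at smaller amounts.
- Compound 2, `COC1=C(C)C(=O)/C(=C(O)/C=C/c2ccccc2OC)C(=O)C1(C)C`, gives 2.4 ug/mL in this assay.

Both compounds share one core and differ only in the aromatic group attached at the end of the side chain. Within the data shown here, compound 2 is one of just two compounds measured, and the single step available, a 1.7-fold higher number from compound 1 to compound 2 (0.23 log units; within the scatter), lies within the scatter, so compound 2 and compound 1 cannot be separated on this read-out.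

Compound 3, `COC1=C(C)C(=O)/C(=C(O)/C=C/c2cccs2)C(=O)C1(C)C`, changes the same position once more: thiophen-2-yl in place of 2-methoxyphenyl on a double-bonded chain carbon bound to a double-bonded chain carbon. Among the measured compounds shown here, the only measured step that bears on this change is the earlier swap of one aromatic group for another at this same place, a 1.7-fold higher number from compound 1 to compound 2 (0.23 log units; within the scatter), which was small. For the measured compounds named here, with that as the sole guide, and with nothing measured for a five-membered ring, the expectation for compound 3 is a number close to that of compound 2, with no step beyond the scatter in either direction: an expected step of a 1.2-fold lower number from compound 2 to compound 3 (0.08 log units; within the scatter). The estimated value for compound 3 in this assay is therefore 2 ug/mL, with a range from 0.8 ug/mL to 5 ug/mL.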

Compound 3, concentration for half-maximal effect: 4.5 ug/mL
Beside the measured number, compound 3's estimate is 2.3-fold (0.35 log units) below it, within the range that was stated.
By their numbers in this assay, from the lowest: compounds 1, 2 and 3 (each within the scatter of the next, the first and the last beyond it).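

Putting thiophen-2-yl in place of 2-methoxyphenyl gives a 1.9-fold higher number from compound 2 to compound 3 (0.27 log units; within the scatter) in this assay and so does not separate these two compounds, even though a five-membered aromatic ring with a sulfur atom has replaced a six-membered ring of carbon only. Among these compounds, measured against the 4-bromophenyl group, the same ring gives a 3.2-fold higher number from compound 1 to compound 3 (0.51 log units; beyond the scatter) and provides the first step in this small set that clears the usual scatter, showing that the aromatic group at this place can change the number, though only modestly. Nothing measured here accounts for that difference, so the data record the change without giving its cause.

On these data alone, all three compounds carry an aromatic ring at this place, so it remains open how the read-out would respond to an amine, a carboxylic acid or a longer chain there. As far as these compounds go, it is also open whether a bromine atom on the thiophene ring would bring the number closer to that of compound 1, which would help show whether the ring itself or the group on it matters more.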